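Aryl for propyl on the oxadiazole sulfoxide

A few compounds are considered here, and "the series" means these few. Any claim that something is new, unique, unknown or untested is made for them only; others in the source may bear on it.

Measured compounds:
compound 1 `CCCc1nnc([S+]([O-])Cc2ncc(C)c(OC)c2C)o1`, 8000 nM
compound 2 `[O-][S+](Cc1ccccc1)c1nnc(-c2cccnc2)o1`, 6000 nM

In a functional assay on HUVEC cells (Homo sapiens) for inhibition, read by ELISA (a lower number here means a stronger inhibitor, a higher number a weaker inhibitor), compound 1 gives 8000 nM, the highest of the two numbers, while compound 2 gives 6000 nM, a difference within the scatter. Compound 3 `COc1c(C)cnc(C[S+]([O-])c2nnc(-c3cccn3C)o2)c1C` is not yet measured. It differs from compound 1 by 1-methyl-1H-pyrrol-2-yl in place of propyl on an aromatic carbon. Compound 2 carries an aromatic ring at a comparable site and its value stands close to that of compound 1, so no step beyond the scatter is expected in this assay, with a 1.3-fold lower number from compound 1 to compound 3 (0.12 log units; within the scatter) as the expected step. For compound 3 the estimated value is 6000 nM, within 1500 nM to 25000 nM.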

Compound 3, half-maximal inhibitory concentration: 4000 nM
Compound 3: middle estimate off by 1.5-fold (0.18 log units), on the high side; the measured number falls inside the stated range.
By their numbers in this assay, from the lowest: compounds 3, 2 and 1 (each within the scatter of the next).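

In this assay, 1-methyl-1H-pyrrol-2-yl in place of propyl gives a 2.0-fold lower number from compound 1 to compound 3 (0.30 log units; within the scatter) and so shows that this aromatic carbon takes a five-membered aromatic ring instead of a propyl chain with no step beyond the scatter. Compound 1 and compound 2 differ in more than one place, so they could not show this for a single change. Nothing at hand bears on why the two groups read alike. Open, from the compounds shown here alone, is whether an amine, a carboxylic acid or a longer chain on this carbon would give a step beyond the scatter.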